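Chloro for methoxy on the aryl piperazine of compound 3

This account rests on a few compounds, and the source may have more. Where it says the series, first, only, none or still open, it means among the compounds named here.

Of the compounds shown here, three built on one shared core have been tested in an ADME assay on NIH3T3 cells (Mus musculus) for cytotoxicity, read by MTT assay, with a stated time of 24 h; a lower number here means a stronger inhibitor, a higher number a weaker inhibitor. Compound 1 `COc1ccccc1N1CCN(CC(=O)N2CCN(c3nnc(-c4ccccc4)c(-c4ccccc4)n3)CC2)CC1` gives 444000 nM. Compound 2 `O=C(CN1CCN(c2ccccc2Cl)CC1)N1CCN(c2nnc(-c3ccccc3)c(-c3ccccc3)n2)CC1` gives 350000 nM, and compound 3 `COc1cccc(N2CCN(CC(=O)N3CCN(c4nnc(-c5ccccc5)c(-c5ccccc5)n4)CC3)CC2)c1` gives 361000 nM. Compound 3 stands second highest of the three numbers, but all three lie within the scatter of one another: the step of a 1.2-fold lower number from compound 1 to compound 3 (0.09 log units; within the scatter) and the step of a 1.0-fold higher number from compound 2 to compound 3 (0.01 log units; within the scatter) are both small, so no order among the three can be read from them.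

The unmeasured compound 4 `O=C(CN1CCN(c2cccc(Cl)c2)CC1)N1CCN(c2nnc(-c3ccccc3)c(-c3ccccc3)n2)CC1` differs from compound 3 in one place: chloro in place of methoxy on an aromatic carbon. Within the data shown here, one measured step bears directly on this kind of change. The exchange of methoxy for chloro on an aromatic carbon, going from compound 1 to compound 2, gave a 1.3-fold lower number from compound 1 to compound 2 (0.10 log units; within the scatter). Nothing in the three measured compounds suggests that the same exchange on compound 3 should behave differently, so the step is expected to be a 1.1-fold lower number from compound 3 to compound 4 (0.04 log units; within the scatter), with no movement beyond the scatter in either direction. Compound 4 is accordingly estimated at 330000 nM in this assay, with a range from 180000 nM to 600000 nM.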

Compound 4, half-maximal inhibitory concentration: 178000 nM
Estimate against measurement, compound 4: 1.9-fold (0.27 log units) above, outside the stated range (below it).
By their numbers in this assay, from the lowest: compounds 4, 2, 3 and 1 (each within the scatter of the next, the first and the last beyond it).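

Among these compounds, on the 3-methoxyphenyl side, chloro in place of methoxy gives a step that clears the scatter in this assay, with a 2.0-fold lower number from compound 3 to compound 4 (0.31 log units; beyond the scatter) and no such step among the earlier compounds. With 3-chlorophenyl in place of 2-methoxyphenyl the step is a 2.5-fold lower number from compound 1 to compound 4 (0.40 log units; beyond the scatter) and is also beyond the scatter, whereas 3-chlorophenyl in place of 2-chlorophenyl gives a 2.0-fold lower number from compound 2 to compound 4 (0.29 log units; within the scatter) and stays within it. Among the compounds shown here, the chloro exchange therefore goes the same way on both cores, although only one of its two steps clears the scatter, and the two steps cannot be told apart: the same change on two cores in this assay, a 1.3-fold lower number (0.10 log units; within the scatter) from compound 1 to compound 2 and a 2.0-fold lower number (0.31 log units; beyond the scatter) from compound 3 to compound 4, 1.6-fold (0.20 log units) apart, within the scatter of two such steps.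

The compounds shown carry only methoxy and chloro on this aromatic ring, so it remains open whether an amine, a nitrile or a trifluoromethyl group in place of the chloro group of compound 4 would keep the number as low or shift it further. All the numbers also come from a single cell line at a single stated time, which leaves open whether this modest step would hold in other cells.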